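Naphthyloxy series: nitrophenyl to dihydroxyphenyl

The source may report more compounds than this note shows. Statements on the series, on what has been measured and on what is new or still open speak of the compounds shown alone.

Measured in an ADME assay on MT4 cells (Homo sapiens) for cytotoxicity, read by MTT assay, with a stated time of 4 days; on this read-out higher numbers stand for lower toxicity in this test and lower numbers for higher toxicity in this test:
- compound 1 `C/C(=N\NC(=O)COc1cccc2ccccc12)c1cccc([N+](=O)[O-])c1`: 12.1 ug/mL
- compound 2 `COc1cc(/C=N/NC(=O)COc2cccc3ccccc23)cc(OC)c1OC`: 13.4 ug/mL
- compound 3 `O=C(COc1cccc2ccccc12)N/N=C/c1cccc([N+](=O)[O-])c1`: 12.1 ug/mL

Compound 1 stands level with compound 3 at the digits shown, and compound 2 lies within the scatter of both.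

Compound 4 `C/C(=N\NC(=O)COc1cccc2ccccc12)c1ccc(O)cc1O` is not yet measured. It carries 2,4-dihydroxyphenyl in place of 3-nitrophenyl on a carbon with a double bond to nitrogen.

Going by the values given here, no measured pair isolates this change, so any expectation rests on the closeness of the three values alone. Expected is a 1.0-fold higher number from compound 1 to compound 4 (0.01 log units; within the scatter), with no step beyond the scatter in either direction. For compound 4 the estimated value is 12.5 ug/mL, with an expected range of 5 ug/mL to 30 ug/mL.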

Compound 4, half-maximal cytotoxic concentration: 59.9 ug/mL
For compound 4 the middle estimate is 4.8-fold (0.68 log units) below the measured one, outside the stated range (above it).
By their numbers in this assay, from the lowest: compounds 1, 3 and 2 (each within the scatter of the next); then compound 4.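

In this assay, 2,4-dihydroxyphenyl in place of 3-nitrophenyl on a carbon with a double bond to nitrogen gives a 5.0-fold higher number from compound 1 to compound 4 (0.69 log units; beyond the scatter), so the group at this place can shift the read-out beyond the scatter. The direction is toward lower toxicity in this test. Nothing on hand accounts for the step.

Open, as far as these compounds go, is whether a phenyl carrying a single hydroxyl, or an amine in place of the hydroxyls, would give the same shift. Also open, from the compounds shown here alone, is whether the change carries over to the core of compound 3.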